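Swapping one core methoxy on compound 1 for hydrogen

A few compounds are considered here, and "the series" means these few. Any claim that something is new, unique, unknown or untested is made for them only; others in the source may bear on it.

Measured in a functional assay on MIA PaCa-2 cells (Homo sapiens) for antiproliferative activity, read by sulforhodamine B assay, with a stated time of 48 h; a lower number here means a stronger inhibitor, a higher number a weaker inhibitor:
Compound 1 `COc1cc(C(=O)/C=C\Nc2ccc(-c3nc4cc(OC)c(OC)c(OC)c4s3)cc2C)cc([N+](=O)[O-])c1OC`: 22000 nM
Compound 2 `COc1cc(OC)c2sc(-c3ccc(N/C=C\C(=O)c4ccc(OC)c(O)c4)cc3)nc2c1`: 11600 nM
Compound 3 `COc1ccc(C(=O)/C=C\Nc2ccc(-c3nc4cc(OC)c(OC)c(OC)c4s3)cc2C)cc1[N+](=O)[O-]`: 23400 nM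

Compound 1 lies within the usual scatter of both compound 2 and compound 3. The untested compound 4 `COc1cc(OC)c2sc(-c3ccc(N/C=C\C(=O)c4cc(OC)c(OC)c([N+](=O)[O-])c4)c(C)c3)nc2c1` changes compound 1 by hydrogen in place of methoxy on an aromatic carbon of the core. The same kind of swap, made elsewhere in the molecule, gave a 1.1-fold higher number from compound 1 to compound 3 (0.03 log units; within the scatter). The core of compound 4 also occurs in compound 2, which differs in other places and gives 11600 nM. In this assay, the expected change is therefore no larger than the scatter, and the estimated step is a 1.3-fold lower number from compound 1 to compound 4 (0.11 log units; within the scatter). For compound 4 the expected value is 17000 nM, with an estimated range of 7000 nM to 45000 nM.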

Compound 4, half-maximal inhibitory concentration: 10400 nM
Compound 4: middle estimate off by 1.6-fold (0.21 log units), on the high side, within the range that was stated.
By their numbers in this assay, from the lowest: compounds 4, 2, 1 and 3 (each within the scatter of the next, the first and the last beyond it).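

Hydrogen in place of methoxy on this carbon of the core gives a 2.1-fold lower number from compound 1 to compound 4 (0.33 log units; beyond the scatter) in this assay. The same kind of swap elsewhere in the molecule gives a 1.1-fold higher number from compound 1 to compound 3 (0.03 log units; within the scatter), so the core position is the one of the two where this swap is printed as beyond the scatter, though the step is modest. No measurement shown accounts for this step.

Still open, from the compounds shown here alone, is how an amine or a fluorine atom on this carbon would compare with hydrogen and methoxy. Also open, going by these compounds, is whether the step would recur in compounds without the nitro group.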